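Methylation of the ring nitrogen in two cores

A few compounds are considered here, and "the series" means these few. Any claim that something is new, unique, unknown or untested is made for them only; others in the source may bear on it.

Values in an assay on isolated protein for inhibition of RAC-alpha serine/threonine-protein kinase (Homo sapiens), read by mobility shift assay, tested at 30 uM; a higher number here means more inhibition at the concentration tested (going by the name of the read-out), a lower number less inhibition:
- compound 1 `Nc1n[nH]c2cc(-c3ccccn3)[nH]c(=O)c12` gives 2%
- compound 2 `Cc1cc2[nH]nc(N)c2c(N2CCCCC2)n1` gives 36%
- compound 3 `Cn1nc(N)c2c(=O)[nH]c(-c3ccccn3)cc21` gives 7%

Compound 1 and compound 3 differ by methyl in place of hydrogen on an aromatic nitrogen, and this step moves the read-out by a number 5 percentage points higher from compound 1 to compound 3 (within the scatter). Compound 2 holds the highest of the three values, its gaps to compound 1 and compound 3 both lying beyond the scatter; how its core differs from that of compound 1 is not broken down here. Compound 4 `Cc1cc2c(c(N)nn2C)c(N2CCCCC2)n1` is not yet measured and differs from compound 2 by methyl in place of hydrogen on an aromatic nitrogen, the same change at the same place. The step is expected to be a number 4 percentage points higher from compound 2 to compound 4 (within the scatter), resting on the earlier one, a number 5 percentage points higher from compound 1 to compound 3 (within the scatter), which stayed within the scatter, and on the starting value of compound 2. Compound 4 is thus estimated at 40%, between 24% and 56%.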

Compound 4, a percentage reported as inhibition, at one concentration (the size of the read-out at that concentration, not a potency): 6%
Compound 4: middle estimate off by 34 percentage points, on the high side; the whole stated range lies above it.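

In this assay, methyl in place of hydrogen on an aromatic nitrogen does not carry over from one core to the other, the new step being a number 30 percentage points lower from compound 2 to compound 4 (beyond the scatter), and the two steps disagree: the same change on two cores in this assay, a number 5 percentage points higher (within the scatter) from compound 1 to compound 3 and a number 30 percentage points lower (beyond the scatter) from compound 2 to compound 4, 35 percentage points apart, beyond the scatter of two such steps

Among these compounds, a step read on one of these cores is therefore no guide to the same change on the other, though this rests on only two pairs. The pairs do not show which feature of the cores sets the difference, and compound 1, at 2%, leaves little room for a fall to be seen.

Still open, as far as these compounds go, is how a longer chain on the same nitrogen, such as ethyl or a chain ending in an amine, would read on either core. Also open, from the compounds shown here alone, is whether any other group on that nitrogen of compound 2 keeps its value.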